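Shifting a Hydroxyl Group: What Compound 3 Might Give

The source may hold more compounds than are shown below. What is called first, only, known or untested is meant among the compounds shown, and "the series" means these compounds.

Compound 1 `Oc1cccc(-c2cc(-c3ccccc3F)cc(-c3ccccc3O)n2)c1` — 24200 nM
Compound 2 `Oc1ccc(-c2cc(-c3ccccc3F)cc(-c3ccccc3O)n2)cc1` — > 50000 nM (a limit of the assay)

Among the compounds with values here, in a functional assay on T47D cells (Homo sapiens) for inhibition (a higher number here means a weaker inhibitor, a lower number a stronger inhibitor), compound 1 gives 24200 nM, the only plain number in this small set. For compound 2 this assay reports only a limit, > 50000 nM. Within the data shown here, the single measured step, an at least 2.0-fold higher number from compound 1 to compound 2 (0.31 log units; beyond the scatter), rests on the limit of > 50000 nM in this assay, at which 1 of the 2 values shown sits, and so is known only as a lower bound on its size.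

Compound 3 `Oc1cccc(-c2cc(-c3ccccc3F)cc(-c3cccc(O)c3)n2)c1` is the next compound in line. It differs from compound 1 by 3-hydroxyphenyl in place of 2-hydroxyphenyl on an aromatic carbon. Among the measured compounds shown here, no measured step covers this exact exchange. For the measured compounds named here, the one step that exists shows that moving the hydroxyl group around a phenyl ring changed the number beyond the scatter, so a similar shift here is plausible, though its direction cannot be read from one step alone. Given the weak starting point of compound 1, the outcome is expected to stay in the same weak region, with a real chance of falling to a limit.

Compound 3 is therefore expected to give 30000 nM, with a range from 10000 nM to 100000 nM. This estimate means an expected step of a 1.2-fold higher number from compound 1 to compound 3 (0.09 log units; within the scatter).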

Compound 3, half-maximal inhibitory concentration: 4370 nM
Compound 3: the middle estimate sits 6.9-fold (0.84 log units) above what was measured; the measured number lies below the stated range.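

In this assay, 3-hydroxyphenyl in place of 2-hydroxyphenyl on the aromatic carbon next to the ring nitrogen brings a 5.5-fold lower number from compound 1 to compound 3 (0.74 log units; beyond the scatter). The group that leaves and the group that enters have the same atoms and the same counts of hydrogen-bond donors and acceptors, so the only difference is where the hydroxyl sits on the ring, and that alone moves the number beyond the scatter. The earlier step, an at least 2.0-fold higher number from compound 1 to compound 2 (0.31 log units; beyond the scatter), moved a hydroxyl on the other hydroxyphenyl ring and went the opposite way, so in these compounds a shift of the hydroxyl can either raise or lower the number, depending on the ring and the place.

Compound 2 is known only as a limit, so the size of its step stays open: the limit of > 50000 nM in this assay, at which 1 of the 3 values shown sits.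

From the compounds shown here alone, it also remains open whether 4-hydroxyphenyl at this same position, or an amine or a carboxylic acid in place of the hydroxyl on this ring, would lower the number further or lose what the 3-hydroxyphenyl group gained.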